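Swapping a Pyrazolyl Group for a Carbamoylfluorophenyl Group

A few compounds are considered here, and "the series" means these few. Any claim that something is new, unique, unknown or untested is made for them only; others in the source may bear on it.

Three measured entries set the scene: compound 1 `Cc1nc2ncc(-c3cnn(C)c3)nc2n1Cc1ccc2ncccc2c1`, compound 2 `CC(c1cc2cccnc2cc1F)n1cnc2ncc(-c3cn[nH]c3)nc21` and compound 3 `CCC(c1cc2cccnc2cc1F)n1cnc2ncc(-c3cn[nH]c3)nc21`. In a functional assay on NCI-H1993 cells (Homo sapiens) for inhibition, read by CCK-8 assay, with a stated time of 72 h (a lower number here means a stronger inhibitor, a higher number a weaker inhibitor), compound 1 gives > 10000 nM, which is a limit of the assay and not a number. In this assay, among the compounds with values here, compound 2 gives 187 nM, the only actual number among the three. For compound 3 the entry in this assay reads "not determined" (no result reported), so no result exists to compare.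

Within the data shown here, compound 2 is therefore the sole numerical reference for compound 4 `CC(c1cc2cccnc2cc1F)n1cnc2ncc(-c3ccc(C(N)=O)c(F)c3)nc21`, which is still unmeasured. Going from compound 2 to compound 4, 4-carbamoyl-3-fluorophenyl takes the place of 1H-pyrazol-4-yl on an aromatic carbon (4-carbamoyl-3-fluorophenyl in place of 1H-pyrazol-4-yl on an aromatic carbon). Among the measured compounds shown here, no measured pair shows what a change at this place does, so any forecast is a judgement with a wide margin. A moderate step towards stronger inhibition is expected in this assay. The estimated change is a 3.1-fold lower number from compound 2 to compound 4 (0.49 log units; beyond the scatter). Compound 4 is expected at about 60 nM, with an estimated range of 10 nM to 350 nM.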

Compound 4, half-maximal inhibitory concentration: 19.5 nM
Compound 4: the middle estimate sits 3.1-fold (0.49 log units) above what was measured, and the stated range covers the measured number.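

In this assay, within the data shown here, the first step that can be read at this position is a 9.6-fold lower number from compound 2 to compound 4 (0.98 log units; beyond the scatter). This place on an aromatic carbon of the shared core therefore tolerates the 4-carbamoyl-3-fluorophenyl group, with 10 heavy atoms, in place of 1H-pyrazol-4-yl, with 5, and inhibition gets stronger rather than being lost. Both groups count 1 hydrogen-bond donor and 1 hydrogen-bond acceptor, and nothing measured here explains the size of the step.

Still open, from the compounds shown here alone, is whether the carbamoyl group or the fluorine carries the gain, and how a phenyl ring bearing a carboxylic acid or an amine in place of the carbamoyl group would read in this assay. Compound 3 has no reported result, which leaves the effect of its longer chain unknown.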